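Swapping the amide aryl group in an interleukin-15 inhibitor series

The source may report more compounds than this note shows. Statements on the series, on what has been measured and on what is new or still open speak of the compounds shown alone.

Among the measured compounds shown here, compound 2 `CCCOc1ccc(NC(=O)CCCCCCCSc2nnc(Cc3nn(C)c(=O)c4ccccc34)n2C)cc1` gives 40000 nM in an assay on cells for inhibition of IL15-IL15 receptor (Homo sapiens), read by AlphaScreen, with stated times of 30 min and 1 h (a higher number here means a weaker inhibitor, a lower number a stronger inhibitor), the lowest of the three numbers measured so far. Compound 1 `CC(C)COc1ccc(NC(=O)CCCCCCCSc2nnc(Cc3nn(C)c(=O)c4ccccc34)n2C)cc1` gives 55000 nM, and the step of a 1.4-fold lower number from compound 1 to compound 2 (0.14 log units; within the scatter) does not separate the two. Compound 3 `Cn1c(Cc2nn(C)c(=O)c3ccccc23)nnc1SCCCCCCCC(=O)Nc1ccc(Br)cc1Br` gives 92000 nM; the step of a 2.3-fold higher number from compound 2 to compound 3 (0.36 log units; beyond the scatter) is the only one in this set that lies beyond the scatter, whereas a 1.7-fold higher number from compound 1 to compound 3 (0.22 log units; within the scatter) does not.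

Compound 4 `Cc1ccc(NC(=O)CCCCCCCSc2nnc(Cc3nn(C)c(=O)c4ccccc34)n2C)c(Cl)c1` has not yet been measured in this assay. It differs from compound 2 in one place: 2-chloro-4-methylphenyl in place of 4-propoxyphenyl on an amide-type nitrogen. For the measured compounds named here, the step that bears most directly on this change is the one from compound 2 to compound 3, where another halogen-bearing phenyl took the place of the 4-propoxyphenyl on the amide-type nitrogen and the number rose modestly. A rise of similar or smaller size is therefore expected here, though it may stay within the scatter. Compound 4 is expected to give about 60000 nM, within a range from 30000 nM to 130000 nM. The step that this estimate implies is a 1.5-fold higher number from compound 2 to compound 4 (0.18 log units; within the scatter).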

Compound 4, half-maximal inhibitory concentration: 76000 nM
The estimate for compound 4 lay 1.3-fold (0.10 log units) below the measured number, and the stated range covers the measured number.
By their numbers in this assay, from the lowest: compounds 2, 1, 4 and 3 (each within the scatter of the next, the first and the last beyond it).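

In this assay, the 2-chloro-4-methylphenyl group on the amide-type nitrogen is not separated from the 4-propoxyphenyl group by a 1.9-fold higher number from compound 2 to compound 4 (0.28 log units; within the scatter), from the 2,4-dibromophenyl group by a 1.2-fold lower number from compound 3 to compound 4 (0.08 log units; within the scatter), or from the 4-(isobutoxy)phenyl group by a 1.4-fold higher number from compound 1 to compound 4 (0.14 log units; within the scatter). At this position, then, 4-propoxyphenyl can give way to a halogen-bearing phenyl without a step beyond the scatter, which the 2,4-dibromophenyl of compound 3 did not manage against compound 2.

The compounds shown leave open whether an amine or a carboxylic acid on this phenyl ring, or a saturated ring in its place, would give a step beyond the scatter of this set. They also leave open what a shorter chain would do in place of the one shared by all four compounds. No measurement given here accounts for how close these numbers lie.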